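The source may report more compounds than this note shows. Statements on the series, on what has been measured and on what is new or still open speak of the compounds shown alone.

Compound 1 `COc1ccccc1/C=c1/[nH]c(=O)/c(=C\c2cccc(Cl)c2Cl)[nH]c1=O` carries a methoxyphenyl methylidene arm on one side of the shared core and a doubly chlorinated phenyl methylidene arm on the other, with hydrogen on both ring nitrogens. In a functional assay on A549 cells (Homo sapiens) for cytotoxicity, read by CCK-8 assay, with a stated time of 72 h (a lower number here means a stronger inhibitor, a higher number a weaker inhibitor), compound 1 gives "not active" (no number reported), so no number stands for it. Two further members of the series are known. Compound 2 `C=CCn1c(=O)/c(=C\c2ccc(Cl)c(Cl)c2)[nH]c(=O)/c1=C\c1ccccc1OC` carries an allyl on one ring nitrogen together with a differently substituted doubly chlorinated phenyl arm; in this assay compound 2 gives "not active" (no number reported). Among the measured compounds shown here, compound 3 `C=CCn1c(=O)/c(=C\c2ccccc2OC)[nH]c(=O)/c1=C\c1ccccc1OC` carries the allyl together with two methoxyphenyl methylidene arms; in this assay compound 3 gives 22400 nM, the only number recorded so far. No pair among these three differs in a single place, so no step size can be read from the measured compounds.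

Compound 4 `COc1ccccc1/C=c1\c(=O)[nH]/c(=C/c2cccc(Cl)c2Cl)c(=O)n1C` is the next candidate. It differs from compound 1 by methyl in place of hydrogen on an aromatic nitrogen. With compound 1 giving "not active" (no number reported) and with compound 2 giving "not active" (no number reported), alkylation of the ring nitrogen has not so far produced a number alongside the chlorinated arm that both of these compounds carry. Compound 4 is therefore expected to remain weak, with an estimated value of 40000 nM in a range from 15000 nM to 150000 nM, and a substantial chance that this assay again reports no number.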

Compound 4, half-maximal inhibitory concentration: 200 nM
The estimate for compound 4 lay 200-fold (2.30 log units) above the measured number, outside the stated range (below it).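

No step can be read from compound 1 to compound 4: in this assay compound 1 gives "not active" (no number reported), whereas compound 4 gives 200 nM. The compounds shown leave open how large a change methyl in place of hydrogen on the aromatic nitrogen brings. No measurement at hand offers an explanation for this result.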